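Terphenyl benzimidazoles: chloro for dimethylamino swap

The source may report more compounds than this note shows. Statements on the series, on what has been measured and on what is new or still open speak of the compounds shown alone.

Measured compounds:
compound 1, `Cc1ccc2[nH]c(-c3ccc(-c4ccc(-c5ccc(N(C)C)cc5)cc4)cc3)nc2c1`: 7200 nM
compound 2, `Cc1ccc2[nH]c(-c3ccc(-c4ccc(-c5cccc(Cl)c5)cc4)cc3)nc2c1`: 3450 nM
compound 3, `CN(C)c1ccc(-c2ccc(-c3ccc(-c4nc5c(O)cccc5[nH]4)cc3)cc2)cc1`: 4100 nM

All three were tested in a functional assay on ZR-75-1 cells (Homo sapiens) for inhibition, read by sulforhodamine B assay; on this read-out lower numbers stand for stronger inhibition of growth and higher numbers for weaker inhibition of growth. Compound 1 gives 7200 nM, compound 2 gives 3450 nM and compound 3 gives 4100 nM. The change from compound 1 to compound 2 is 3-chlorophenyl in place of 4-(dimethylamino)phenyl on an aromatic carbon and it made a 2.1-fold lower number from compound 1 to compound 2 (0.32 log units; beyond the scatter). Compound 1 and compound 3 differ in the core, (4-hydroxy-1H-benzimidazol-2-yl in place of 5-methyl-1H-benzimidazol-2-yl on an aromatic carbon), and the move between them is a 1.8-fold lower number from compound 1 to compound 3 (0.24 log units; within the scatter), so the two cores cannot be told apart on these numbers.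

Compound 4, `Oc1cccc2[nH]c(-c3ccc(-c4ccc(-c5cccc(Cl)c5)cc4)cc3)nc12`, has not yet been tested in this assay. It relates to compound 3 as compound 2 relates to compound 1: 3-chlorophenyl in place of 4-(dimethylamino)phenyl on an aromatic carbon. The place of the change is the same in both pairs, so it is the same change seen a second time. Going by the values given here, only one earlier instance exists, with no check on how it carries across cores, so the expectation is loose. For compound 4 in this assay the step is estimated as a 2.1-fold lower number from compound 3 to compound 4 (0.31 log units; beyond the scatter), resting on the step from compound 1 to compound 2, a 2.1-fold lower number from compound 1 to compound 2 (0.32 log units; beyond the scatter). Compound 4 is therefore expected at about 2000 nM, with a likely range from 1000 nM to 4200 nM.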

Compound 4, concentration for 50% growth inhibition: 2410 nM
Compound 4: middle estimate off by 1.2-fold (0.08 log units), on the low side; low and high end bracket the measured number.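

In this assay the change to 3-chlorophenyl in place of 4-(dimethylamino)phenyl, taken onto the core of compound 3, comes out as a 1.7-fold lower number from compound 3 to compound 4 (0.23 log units; within the scatter) and so cannot be told from scatter when read alone. Two cores with one pair each show nothing general: they do not establish that the step would keep its size on any further core, and they do not separate the effect of the two cores from each other. Read together, the two instances do not differ in size, so on these two cores the change carries over as far as the numbers can resolve: the same change on two cores in this assay, a 2.1-fold lower number (0.32 log units; beyond the scatter) from compound 1 to compound 2 and a 1.7-fold lower number (0.23 log units; within the scatter) from compound 3 to compound 4, 1.2-fold (0.09 log units) apart, within the scatter of two such steps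

The compounds shown hold only 3-chlorophenyl and 4-(dimethylamino)phenyl at this place, so 4-chlorophenyl, unsubstituted phenyl, or a phenyl bearing a carboxylic acid or an amine on a longer chain remain open there. On the core side, only methyl and hydroxy appear, which leaves a methoxy group or a fluorine open.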